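The source may report more compounds than this note shows. Statements on the series, on what has been measured and on what is new or still open speak of the compounds shown alone.

In an ADME assay on J774 cells (Mus musculus) for cytotoxicity, read by fluorescence and resazurin assay, with a stated time of 24 h (a higher number here means that more compound is tolerated, a lower number that less compound is tolerated), the result for compound 2 `O=[N+]([O-])c1ccc(S(=O)(=O)Nc2ccc3cn[nH]c3c2)cc1` is a limit and not a number: >= 300000 nM. Compound 3 `O=S(=O)(Nc1ccc2cn[nH]c2c1)c1ccc(F)cc1` departs from compound 2 in one place, (fluoro in place of nitro on an aromatic carbon), with fluoro in place of nitro on an aromatic carbon, para to a large group. Going by the values given here, no step between measured compounds covers this change, so any forecast here is indirect. A downward step beyond the scatter is expected in this assay, with less compound tolerated, on the evidence of compound 1 `O=S(=O)(Nc1ccc2nccnc2c1)c1ccc(F)cc1`, which also bears a fluoro group and gives 43900 nM. A result at the limit again cannot be ruled out. In numbers, the expected move is an at least 2.7-fold lower number from compound 2 to compound 3 (0.43 log units; beyond the scatter). Compound 3 is estimated at 110000 nM, with an expected range from 35000 nM to 300000 nM.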

Compound 3, half-maximal cytotoxic concentration: >= 300000 nM
Compound 3 gave a limit, no number; the forecaster's own chance of this, stated with the estimate: 25%; middle value at least 2.7-fold (0.43 log units) from the limit.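

In this assay compound 2 and compound 3 both stand at a limit and not at a number, so no step can be read between them: the limit of >= 300000 nM in this assay, at which 2 of the 3 values shown sit.

The compounds shown leave open whether fluoro in place of nitro on an aromatic carbon moves the tolerated concentration at all, in either direction.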